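Thiophene-bearing dihydropyrimidinone esters: thioester to branched ester

A few compounds are considered here, and "the series" means these few. Any claim that something is new, unique, unknown or untested is made for them only; others in the source may bear on it.

Measured so far:
compound 1 `CC1=C(C(=O)OC(C)(C)C)C(c2cccs2)NC(=O)N1`: 26%
compound 2 `CC1=C(C(=O)SC(C)C)C(c2cccs2)NC(=O)N1`: 1%

Within the data shown here, in an assay on membranes from CHO cells for displacement of a labelled ligand from adenosine receptor A1 (Homo sapiens), read by scintillation counting, with a stated time of 60 min, tested at 1 uM (on this read-out lower numbers stand for less inhibition and higher numbers for more inhibition at the one concentration tested (going by the name of the read-out)), compound 2 gives the lowest of the two numbers known; its nearest neighbour is compound 1, with a number 25 percentage points lower from compound 1 to compound 2 (beyond the scatter) separating them.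

Compound 3 `CCC(CC)OC(=O)C1=C(C)NC(=O)NC1c1cccs1` differs from compound 2 by (pentan-3-yl)oxy in place of isopropylsulfanyl on a carbonyl carbon.

Among the measured compounds shown here, only one measured step bears on this change. It is the step of a number 25 percentage points lower from compound 1 to compound 2 (beyond the scatter), where isopropylsulfanyl replaced tert-butoxy on the carbonyl carbon and the read-out fell beyond the scatter. The move to compound 3 restores an oxygen-linked branched alkoxy group on that carbonyl carbon, so a step in the opposite direction, back toward the level of compound 1, is expected; the alkyl portion is not the same, so the size is uncertain.

Compound 3 is therefore estimated at 20% (range 5% to 40%), which is an expected step of a number 19 percentage points higher from compound 2 to compound 3 (beyond the scatter).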

Compound 3, a percentage reported as inhibition, at one concentration (the size of the read-out at that concentration, not a potency): 13%
The estimate for compound 3 lay 7 percentage points above the measured number; the range from low to high includes it.
By their numbers in this assay, from the lowest: compound 2; then compound 3; then compound 1.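

In this assay, the (pentan-3-yl)oxy group on the carbonyl carbon gives a higher number than isopropylsulfanyl (a number 12 percentage points higher from compound 2 to compound 3 (beyond the scatter)), although this step changes both the linking atom and the alkyl group. With the oxygen link kept, pentan-3-yl in place of tert-butyl also moves the read-out beyond the scatter (a number 13 percentage points lower from compound 1 to compound 3 (beyond the scatter)), so the alkyl group on the oxygen matters in its own right at this position. No evidence on hand gives a cause for either step.

The compounds shown include no pair with the same alkyl group on oxygen and on sulfur, so the part played by the linking atom alone stays open. Going by these compounds, how an unbranched chain such as n-butoxy, an amine or a free carboxylic acid at this carbonyl carbon would read also remains open.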